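Moving the Fluorine on the Benzyl Group of Compound 2

A few compounds are considered here, and "the series" means these few. Any claim that something is new, unique, unknown or untested is made for them only; others in the source may bear on it.

Of the compounds shown here, three built on one shared core have been tested in a functional assay on MCF7 cells (Homo sapiens) for cytotoxicity, read by MTT assay, with a stated time of 72 h; on this read-out higher numbers stand for weaker inhibition and lower numbers for stronger inhibition. Compound 1 `CC(C)NC(=O)N1CCN(C(=S)SCc2cn(Cc3ccccc3F)nn2)CC1` gives 1860 nM. Compound 2 `CCN(C)C(=O)N1CCN(C(=S)SCc2cn(Cc3ccccc3F)nn2)CC1` gives 7210 nM, and compound 3 `O=C(NCc1ccccc1)N1CCN(C(=S)SCc2cn(Cc3ccccc3F)nn2)CC1` gives 38100 nM. On these numbers compound 2 stands second highest of the three: the step of a 3.9-fold higher number from compound 1 to compound 2 (0.59 log units; beyond the scatter) separates it from compound 1, the step of a 5.3-fold higher number from compound 2 to compound 3 (0.72 log units; beyond the scatter) separates it from compound 3, and the step of a 20-fold higher number from compound 1 to compound 3 (1.31 log units; beyond the scatter) spans the whole set.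

Compound 4 `CCN(C)C(=O)N1CCN(C(=S)SCc2cn(Cc3ccc(F)cc3)nn2)CC1` keeps everything of compound 2 except one change: 4-fluorophenyl in place of 2-fluorophenyl on a saturated chain carbon bound to an aromatic nitrogen, which read one bond further out is 2-fluorobenzyl to 4-fluorobenzyl. Going by the values given here, none of the measured steps touches this part of the molecule; each of them alters the group on the carbonyl carbon while the 2-fluorobenzyl group stays fixed. So no measured step bears directly on the change from compound 2 to compound 4, and the expectation in this assay is a step of no size beyond the scatter, in either direction. The estimated step is a 1.0-fold lower number from compound 2 to compound 4 (0.00 log units; within the scatter). For compound 4 the estimate in this assay is 7200 nM, within a range from 2500 nM to 21000 nM.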

Compound 4, half-maximal inhibitory concentration: 2150 nM
Beside the measured number, compound 4's estimate is 3.3-fold (0.52 log units) above it; measured number below the stated range.
By their numbers in this assay, from the lowest: compounds 1 and 4 (each within the scatter of the next); then compound 2; then compound 3.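

In this assay the step of a 3.4-fold lower number from compound 2 to compound 4 (0.53 log units; beyond the scatter) shows that where the fluorine sits on the benzyl group matters: with ethyl(methyl)amino held fixed on the carbonyl carbon, 4-fluorobenzyl in place of 2-fluorobenzyl gives stronger inhibition, beyond the scatter. Compounds 1, 2 and 3 all carry 2-fluorobenzyl, so this step is the only one shown in which the group on the aromatic nitrogen, and not the group on the carbonyl carbon, alters the number. Nothing given here accounts for the size or direction of this step.

From the compounds shown here alone, whether the same change would give a like step with isopropylamino or benzylamino on the carbonyl carbon remains open. So does how a benzyl group without fluorine, or one with chlorine or methoxy in place of the fluorine, would read.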